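From ethyl to hydroxy: what compound 3 may show

This account rests on a few compounds, and the source may have more. Where it says the series, first, only, none or still open, it means among the compounds named here.

- Compound 1 `CCCCCCCCCCCCCCC[C@@H](O)[C@@H](N)[C@@H](C)O` gives 19000 nM in a functional assay on HeLa cells (Homo sapiens) for antiproliferative activity, read by sulforhodamine B assay, with a stated time of 48 h; a higher number here means a weaker inhibitor of growth, a lower number a stronger inhibitor of growth
- Compound 2 `CCCCCCCCC[C@@H](O)[C@@H](N)[C@@H](C)CC` gives 20000 nM in this assay

Compound 2 with 20000 nM lies within the scatter of compound 1, so the two cannot be ranked. Compound 3 `CCCCCCCCC[C@@H](O)[C@@H](N)[C@@H](C)O` comes from compound 2 through a single change: hydroxy in place of ethyl on a saturated chain carbon bound to two saturated chain carbons ( hydroxy in place of ethyl on a saturated chain carbon bound to two saturated chain carbons ). Among the measured compounds shown here, no measured pair shows this exchange on its own, so there is no direct guide to its size. With compound 1 at 19000 nM and compound 2 at 20000 nM showing so little spread, no step beyond the scatter is expected, only a slight lean toward weaker growth inhibition. The estimated step is a 1.5-fold higher number from compound 2 to compound 3 (0.18 log units; within the scatter) in this assay and carries real uncertainty. For compound 3 the expected value is 30000 nM within an estimated range from 10000 nM to 100000 nM as the likely span.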

Compound 3, concentration for 50% growth inhibition: 17000 nM
For compound 3 the middle estimate is 1.8-fold (0.25 log units) above the measured one; the measured number falls inside the stated range.
By their numbers in this assay, from the lowest: compounds 3, 1 and 2 (each within the scatter of the next).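

Hydroxy in place of ethyl on a saturated chain carbon bound to two saturated chain carbons now has a measured size: the step of a 1.2-fold lower number from compound 2 to compound 3 (0.07 log units; within the scatter) in this assay stays within the scatter, so this exchange cannot be told from no change, even though hydroxy carries a hydrogen-bond donor and acceptor that ethyl lacks. Hydrogen in place of hexyl on a saturated chain carbon gives a step of a 1.1-fold lower number from compound 1 to compound 3 (0.05 log units; within the scatter) that also stays within the scatter, so this chain difference cannot be read in this assay either. No supporting measurement offers an explanation for these results.

From the compounds shown here alone, whether an amine or a carboxylic acid at the place of the hydroxy would move the number beyond the scatter remains open. So does the effect of a chain longer than that of compound 1.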